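The compounds below may be only part of what the source reports. "The series", "measured", "known", "first", "only" and "open" are said of these compounds alone.

Measured so far:
compound 1 `COc1cc(C)cc(-c2c(-c3ccnc(-c4ccc(C(C)=O)cc4)c3)cnn2CC#N)c1` — 86%
compound 2 `COc1cc(C)cc(-c2nn(CC#N)cc2-c2ccc(-c3cccc(C(C)=O)c3)nc2)c1` — 90%
compound 3 `Cc1cc(O)cc(-c2nn(CC#N)cc2-c2ccnc(-c3ccc(Oc4ccccc4)cc3)c2)c1` — 91%

All three numbers come from a functional assay on BT-549 cells (Homo sapiens) for cytotoxicity, read by sulforhodamine B assay, with a stated time of 48 h, tested at 0.01 uM; on this read-out higher numbers stand for a weaker effect at the one concentration tested and lower numbers for a stronger effect. Compound 3 gives 91% in this assay, and its number sits at the top of the three, but the gap to compound 2 and the gap to compound 1 both fall inside the usual scatter, so the three compounds cannot be told apart on these figures. Each of them leaves most of the cell growth untouched at the single concentration tested.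

Compound 4 `Cc1cc(O)cc(-c2nn(CC#N)cc2-c2ccnc(-c3ccc(N(C)C)cc3)c2)c1` has not been measured. It differs from compound 3 in one place: dimethylamino in place of phenoxy on an aromatic carbon. For the measured compounds named here, no step between two measured compounds covers a change of this kind, so there is nothing in the measured set to read a direction from. Given that compound 1, compound 2 and compound 3 all land within the scatter of one another despite their own differences, a step of no size beyond the scatter is expected in this assay, as a number 3 percentage points lower from compound 3 to compound 4 (within the scatter) expresses.

Compound 4 is therefore expected to give about 88% in this assay, within a range from 74% to 100%.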

Compound 4, a percentage reported as activity, at one concentration (the size of the read-out at that concentration, not a potency): 91%
Compound 4: the middle estimate sits 3 percentage points below what was measured, and the stated range covers the measured number.
By their numbers in this assay, from the lowest: compounds 1, 2, 3 and 4 (each within the scatter of the next).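

In this assay, for the compounds shown here, dimethylamino in place of phenoxy on an aromatic carbon, para to a large group, gives no change at the digits printed from compound 3 to compound 4 (within the scatter), the only step so far that isolates a change in one place. At this position, then, a group of 3 heavy atoms with no ring stands in for one of 7 heavy atoms carrying a six-membered aromatic ring, and the read-out does not register the exchange at the one concentration tested. Nothing in the data bears on why the two groups read alike.

Going by these compounds, whether a carboxylic acid, a morpholine ring or a primary amine at this same place would shift the read-out beyond the scatter remains open, and so does whether any group here can produce a step at all. A single concentration at which most cell growth remains also leaves open whether compound 3 and compound 4 would separate at other concentrations, so the step marks no difference at this one concentration and does not establish equal potency.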